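Dropping One Methoxy Group: A Small Expected Step

The compounds below may be only part of what the source reports. "The series", "measured", "known", "first", "only" and "open" are said of these compounds alone.

Of the compounds shown here, three have been measured in a functional assay on A549 cells (Homo sapiens) for inhibition, read by colorimetric assay and MTT assay, with a stated time of 72 h; a lower number here means a stronger inhibitor, a higher number a weaker inhibitor. Compound 1 `COc1ccc(-c2cc(NC(=S)NNC(=O)c3ccc(C)cc3)cs2)cc1` gives 35000 nM there. Compound 2 `Cc1ccc(C(=O)NNC(=S)Nc2csc(-c3ccccc3)c2)cc1` gives 40000 nM in this assay, and compound 3 `COc1cc(C(=O)NNC(=S)Nc2csc(-c3ccccc3)c2)cc(OC)c1OC` gives 39000 nM. Compound 1 and compound 2 differ by hydrogen in place of methoxy on an aromatic carbon and this change made the step of a 1.1-fold higher number from compound 1 to compound 2 (0.06 log units; within the scatter). The cores of compound 1 and compound 3 also differ, but that difference is not broken down here.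

Compound 4 `COc1cc(OC)cc(C(=O)NNC(=S)Nc2csc(-c3ccccc3)c2)c1` has not yet been measured. Going by the values given here, it differs from compound 3 by hydrogen in place of methoxy on an aromatic carbon This is the same kind of change as the one from compound 1 to compound 2, but not the same: in compound 3 the place is ortho to two methoxy groups as well as para to a large group, whereas in compound 1 it is only para to a large group.

Because the earlier step of a 1.1-fold higher number from compound 1 to compound 2 (0.06 log units; within the scatter) stayed within the scatter, little movement is expected here. Compound 4 is expected to give about 40000 nM in this assay, most likely between 20000 nM and 80000 nM. The expected step is a 1.0-fold higher number from compound 3 to compound 4 (0.01 log units; within the scatter).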

Compound 4, half-maximal inhibitory concentration: 39000 nM
Compound 4: the middle estimate sits 1.0-fold (0.01 log units) above what was measured, and the stated range covers the measured number.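

In this assay, putting hydrogen in place of a methoxy group on an aromatic carbon gave no change at the digits printed from compound 3 to compound 4 (within the scatter). Set beside the same change on the other core, the new step agrees with the earlier one: the same change on two cores in this assay, a 1.1-fold higher number (0.06 log units; within the scatter) from compound 1 to compound 2 and no change at the digits printed (within the scatter) from compound 3 to compound 4, 1.1-fold (0.06 log units) apart, within the scatter of two such steps. This shows that on these two cores the swap of methoxy for hydrogen leaves the number where it was, so the result carries over in the sense that neither step can be told apart from repeat-measurement noise, but it does not show that the change would stay this quiet on a further core, and two flat steps reveal no real effect that could be said to transfer.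

From the compounds shown here alone, it remains open whether a different group in that place, such as an amine, a carboxylic acid or a longer chain like butoxy, would move the number at all. The compounds shown also leave open whether a change elsewhere on the shared core would matter more than these swaps on the ring.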